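Hydroxyphenyl placement on the shared core: compound 2 to compound 3

The source may hold more compounds than are shown below. What is called first, only, known or untested is meant among the compounds shown, and "the series" means these compounds.

Two compounds of the series have been run in a functional assay on DU-145 cells (Homo sapiens) for cytotoxicity, read by CCK-8 assay and cell counting, with a stated time of 2 days; on this read-out higher numbers stand for weaker inhibition and lower numbers for stronger inhibition. Compound 1 `Oc1cccc(-c2cc(-c3ccc(Cl)cc3)nc(-c3cccnc3)c2)c1` carries a 3-hydroxyphenyl group and a pyridin-3-yl group on the shared core; in this assay compound 1 gives 26800 nM. Compound 2 `Oc1ccc(-c2cc(-c3ccc(Cl)cc3)nc(-c3ccsc3)c2)cc1` carries a 4-hydroxyphenyl group and a thiophen-3-yl group; in this assay compound 2 gives 6940 nM, the lower of the two numbers, and the gap to compound 1 lies beyond the scatter. Compound 1 and compound 2 differ in two places at once, so nothing here separates the contribution of either change.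

Compound 3 `Oc1cccc(-c2cc(-c3ccc(Cl)cc3)nc(-c3ccsc3)c2)c1` is the next member. It differs from compound 2 in one place: 3-hydroxyphenyl in place of 4-hydroxyphenyl on an aromatic carbon. Among the compounds with values here, no single-change pair has been measured, so the size of this step is open. Given that compound 1, the only other member with a 3-hydroxyphenyl group, gives 26800 nM, a modest weakening is expected, though a step within the scatter is also plausible. The expected step from compound 2 to compound 3 in this assay is a 1.7-fold higher number from compound 2 to compound 3 (0.24 log units; within the scatter). Compound 3 is estimated at 12000 nM in this assay, within 4000 nM to 40000 nM.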

Compound 3, half-maximal inhibitory concentration: 11600 nM
The estimate for compound 3 lay 1.0-fold (0.01 log units) above the measured number; measured number inside the range.
By their numbers in this assay, from the lowest: compounds 2 and 3 (each within the scatter of the next); then compound 1.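

In this assay, within the data shown here, 3-hydroxyphenyl in place of 4-hydroxyphenyl, on the aromatic carbon opposite the ring nitrogen, gives the first single-change reading at this position: a 1.7-fold higher number from compound 2 to compound 3 (0.22 log units; within the scatter), so with thiophen-3-yl on the shared core the two hydroxyphenyl placements cannot be told apart. Among these compounds, compound 3 also gives the first single-change reading for the other group, where thiophen-3-yl in place of pyridin-3-yl gives a 2.3-fold lower number from compound 1 to compound 3 (0.36 log units; beyond the scatter), a modest step but one that clears the scatter, so on the present pairs this exchange, not the hydroxyphenyl placement, is the one with a readable effect. No measurement available on the series bears on the reason for either step.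

Among the compounds shown here, whether the hydroxyphenyl placement stays equally silent with pyridin-3-yl on the shared core remains open, since only one pair reads this position and it carries thiophen-3-yl. Also open, on these data alone, is whether an amine or a carboxylic acid in place of the hydroxyl on the 3-hydroxyphenyl group would give a step beyond the scatter.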